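The source may hold more compounds than are shown below. What is called first, only, known or untested is meant among the compounds shown, and "the series" means these compounds.

The measured compounds:

compound 1 `Cn1nnnc1SCC(=O)N/N=C/c1ccccc1` — 9700000 nM
compound 2 `Cn1nnnc1SCC(=O)N/N=C/c1ccc(Br)cc1` — 10000000 nM

In an ADME assay on NIH3T3 cells (Mus musculus) for cytotoxicity, read by XTT assay, with a stated time of 24 h (a lower number here means a stronger inhibitor, a higher number a weaker inhibitor), compound 1 gives 9700000 nM, and compound 2 gives 10000000 nM. For the measured compounds named here, the one measured step, a 1.0-fold higher number from compound 1 to compound 2 (0.01 log units; within the scatter), lies within the scatter, so compound 2 and compound 1 cannot be told apart on these two numbers; compound 2 stands at one end of a pair whose members are indistinguishable.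

Compound 3 `Cn1nnnc1SCC(=O)N/N=C/c1ccc(C(F)(F)F)cc1` is the next member of the series. Its change from compound 2 is trifluoromethyl in place of bromo on an aromatic carbon. Going by the values given here, only the step from compound 1 to compound 2 bears on this change, and that step stayed within the scatter; both measured numbers sit close together. Compound 3 is therefore expected to show no step beyond the scatter, no change at the digits printed from compound 2 to compound 3 (within the scatter). For compound 3 the estimate in this assay is 10000000 nM, with a range from 4000000 nM to 25000000 nM.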

Compound 3, half-maximal inhibitory concentration: > 10000000 nM
Compound 3: a limit, no number; the forecaster's own chance of this, stated with the estimate: 30%; the middle value sits exactly at the limit.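

In this assay, compound 3 gives a limit and not a number: the limit of > 10000000 nM in this assay, at which 1 of the 3 values shown sits.

Against the unsubstituted compound, the reading is an at least 1.0-fold higher number from compound 1 to compound 3 (0.01 log units; that floor lies within the scatter), so only a floor is known and it does not separate the two. Against the bromo compound, the reading is a number no lower from compound 2 to compound 3 (the limit leaves the size open), so trifluoromethyl, with 4 heavy atoms where bromo has 1, brought no lower number at this place, which is the first sign that a group of more heavy atoms there does not move the number downward in this assay.

From the compounds shown here alone, how far compound 3 really lies from compound 1 and compound 2 remains open. So does whether an amine or a carboxylic acid at this same place would give a lower number, since all three compounds shown carry only hydrogen, bromo or trifluoromethyl there.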